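This account rests on a few compounds, and the source may have more. Where it says the series, first, only, none or still open, it means among the compounds named here.

- compound 1 `Fc1cc2nc(-c3cncnc3C(F)(F)F)n(C3CC3)c2cc1F` at 410 nM
- compound 2 `N#Cc1ccc2nc(-c3cncnc3C(F)F)n(C3CC3)c2n1` at 2880 nM

In an ADME assay on the whole organism (Macaca fascicularis) for pharmacokinetics, with a stated time of 72 h, at a dose of 1 mg/kg by the oral route (on this read-out lower numbers stand for lower exposure and higher numbers for higher exposure at the dose given), compound 2 stands highest of the two measured compounds, and compound 1 lies lower, beyond the usual scatter. Compound 3 `N#Cc1ccc2nc(-c3cncnc3C(F)(F)F)n(C3CC3)c2n1` differs from compound 2 in one place by fluoro in place of hydrogen on a saturated chain carbon bound to an aromatic carbon and two fluorine atoms, which reads as difluoromethyl to trifluoromethyl. Going by the values given here, no measured pair isolates this change. The step of a 1.2-fold lower number from compound 2 to compound 3 (0.06 log units; within the scatter) is expected to be slightly downward and to stay within the scatter. For compound 3 the estimated value is 2500 nM with an expected range from 1000 nM to 5500 nM as its upper end.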

Compound 3, maximal plasma concentration: 1680 nM
For compound 3 the middle estimate is 1.5-fold (0.17 log units) above the measured one, and the stated range covers the measured number.
By their numbers in this assay, from the lowest: compound 1; then compounds 3 and 2 (each within the scatter of the next).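

In this assay, going by these compounds alone, the change from difluoromethyl to trifluoromethyl can be read on its own for the first time, as a 1.7-fold lower number from compound 2 to compound 3 (0.23 log units; within the scatter) on the shared core. Thus, on a saturated chain carbon bound to an aromatic carbon and two fluorine atoms, fluoro in place of hydrogen leaves the two numbers within the scatter of each other. Nothing measured here accounts for this result. Still open, going by these compounds, is how a methyl or an amine at this place would read, and whether the same change would read alike on the core of compound 1.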